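Alkenyl amide change from compound 2 to compound 3

The source may hold more compounds than are shown below. What is called first, only, known or untested is meant among the compounds shown, and "the series" means these compounds.

In a functional assay on MCF7 cells (Homo sapiens) for antiproliferative activity, read by MTT assay, with a stated time of 72 h (on this read-out lower numbers stand for stronger inhibition and higher numbers for weaker inhibition), compound 1 `CCC/C=C/C(=O)Nc1cccc(Oc2nc(Nc3cccc(OC)c3)nc3c2CSCC3)c1` gives 32000 nM.

In this assay, compound 2 `COc1cccc(Nc2nc3c(c(Oc4cccc(NC(=O)C=C(C)C)c4)n2)CSCC3)c1` gives > 50000 nM, which is a limit of the assay and not a number.

Compound 3 `COc1cccc(Nc2nc3c(c(Oc4cccc(NC(=O)/C=C/C(C)C)c4)n2)CSCC3)c1` carries 3-methylbut-1-en-1-yl in place of 2-methylprop-1-en-1-yl on a carbonyl carbon.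

Within the data shown here, only one measured step bears on this change, also an exchange of the group on the carbonyl carbon: an at least 1.5-fold higher number from compound 1 to compound 2 (0.19 log units; that floor lies within the scatter). It gives no sign that such exchanges move the read-out by much, so no step beyond the scatter is expected in this assay.

The expected step is an at least 1.2-fold lower number from compound 2 to compound 3 (0.09 log units; that floor lies within the scatter).

For compound 3 the estimate is 40000 nM, with an expected range of 18000 nM to 80000 nM.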

Compound 3, half-maximal inhibitory concentration: 21800 nM
Compound 3: the middle estimate sits 1.8-fold (0.26 log units) above what was measured, and the stated range covers the measured number.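

Among these compounds, on the carbonyl carbon, 3-methylbut-1-en-1-yl in place of 2-methylprop-1-en-1-yl gives an at least 2.2-fold lower number from compound 2 to compound 3 (0.36 log units; beyond the scatter) in this assay, the first step at this position that lies beyond the scatter. The value of compound 2 is a limit of the assay and not a number, so the size of that step is only a floor: the limit of > 50000 nM in this assay, at which 1 of the 3 values shown sits.

Isopropyl in place of propyl on a double-bonded chain carbon bound to a double-bonded chain carbon gives a 1.5-fold lower number from compound 1 to compound 3 (0.17 log units; within the scatter), so the branched and straight chains cannot be told apart here.

The compounds shown leave open how a saturated butyl chain or an alkenyl chain ending in a dimethylamino group on the carbonyl carbon would read in this assay. They also leave open whether a longer branched chain would go beyond the scatter relative to compound 3.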